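The source may hold more compounds than are shown below. What is called first, only, known or untested is meant among the compounds shown, and "the series" means these compounds.

For the measured compounds named here, compound 2, `Cn1c(=O)c(C(=O)Nc2ccc(F)cc2)cc2cnc(Nc3ccc4[nH]ccc4c3)nc21`, is one of two compounds measured in a functional assay on DU-145 cells (Homo sapiens) for inhibition, read by trypan blue exclusion, with a stated time of 72 h; a lower number here means a stronger inhibitor, a higher number a weaker inhibitor. In this assay compound 2 gives 5000 nM. Going by the values given here, the only other measured compound is compound 1, `Cn1c(=O)c(S(=O)(=O)c2ccc(C(=O)O)cc2)cc2cnc(Nc3ccc4[nH]ccc4c3)nc21`, and in this assay compound 1 gives 10000 nM; the gap between the two numbers is within the usual scatter, so the two compounds cannot be told apart on these data.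

Compound 3, `COc1ccc(S(=O)(=O)c2cc3cnc(Nc4ccc5[nH]ccc5c4)nc3n(C)c2=O)cc1`, has not been measured in this assay. It differs from compound 2 in one place: (4-methoxyphenyl)sulfonyl in place of (4-fluorophenyl)carbamoyl on an aromatic carbon. Among the compounds with values here, no pair of measured compounds differing in one place is available, so there is no measured step to lean on.

With both measured numbers weak and close to each other, the account expects compound 3 to land near compound 2, with a step from compound 2 to compound 3 of no change at the digits printed from compound 2 to compound 3 (within the scatter) in this assay, not clearly beyond the scatter in either direction. The estimate for compound 3 in this assay is 5000 nM, with a range from 1200 nM to 20000 nM.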

Compound 3, half-maximal inhibitory concentration: 500 nM
Beside the measured number, compound 3's estimate is 10-fold (1.00 log units) above it, outside the stated range (below it).
By their numbers in this assay, from the lowest: compound 3; then compounds 2 and 1 (each within the scatter of the next).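

Changing (4-fluorophenyl)carbamoyl to (4-methoxyphenyl)sulfonyl on this aromatic carbon gives a 10-fold lower number from compound 2 to compound 3 (1.00 log units; beyond the scatter) in this assay, so this position can move the number beyond the scatter, something the two earlier compounds, within the scatter of each other, could not show. The sulfonyl link alone does not account for the result, as compound 1 carries it too, and methoxy in place of carboxy on the phenyl ring of that group gives a 20-fold lower number from compound 1 to compound 3 (1.30 log units; beyond the scatter) in this assay, so the group on the ring also matters while the link stays the same. No measurement here bears on why either step occurs.

The compounds shown do not separate the two parts of the change from compound 2 to compound 3, the link and the ring group, which a (4-fluorophenyl)sulfonyl or a (4-methoxyphenyl)carbamoyl group would pull apart. As far as these compounds go, how far the methoxy result extends to other groups on that ring, such as an amine, a hydroxyl or a longer ether chain, also remains open.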